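The compounds below may be only part of what the source reports. "The series", "measured", "known", "first", "only" and "open" are said of these compounds alone.

Compound 1 `FC(F)(F)c1cccc(-c2nc3cnc(Nc4ccccn4)cc3[nH]2)c1`: 47%
Compound 2 `FC(F)(F)Oc1ccc(-c2nc3cnc(Nc4ccccn4)cc3[nH]2)cc1`: 62%

In an ADME assay on microsomes from liver (Mus musculus) for metabolic stability, read by LC-MS, with a stated time of 30 min, tested at 0.1 uM (on this read-out higher numbers stand for a more stable compound and lower numbers for a less stable compound), compound 1 gives 47%, the lower of the two numbers shown. Compound 2 gives 62%, a number higher by a step beyond the scatter. Compound 3 `COc1cccc(Nc2cc3[nH]c(-c4cccc(C(F)(F)F)c4)nc3cn2)n1` differs from compound 1 by methoxy in place of hydrogen on an aromatic carbon. Going by the values given here, no measured pair shows this particular change, so the data give nothing to size it against. For this change only a small step is expected, a number 5 percentage points lower from compound 1 to compound 3 (within the scatter), with no clear direction beyond the scatter. Compound 3 is therefore estimated at 42%, within a range from 25% to 60%.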

Compound 3, percent of the compound remaining: 60%
Estimate against measurement, compound 3: 18 percentage points below, and the stated range covers the measured number.
By their numbers in this assay, from the lowest: compound 1; then compounds 3 and 2 (each within the scatter of the next).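

In this assay, the change from (pyridin-2-yl)amino to (6-methoxypyridin-2-yl)amino comes with a number 13 percentage points higher from compound 1 to compound 3 (beyond the scatter). Going by these compounds alone, this is the first step read at any position, and it shows that methoxy on this aromatic carbon next to the ring nitrogen raises the number rather than lowering it. No measurement shown accounts for the rise. A single group at this carbon cannot show whether the step is specific to methoxy or would also appear with a methyl, a fluorine or an amine. From the compounds shown here alone, whether the same change would raise the number for compound 2 also stays open.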